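The source may hold more compounds than are shown below. What is called first, only, known or untested is meant among the compounds shown, and "the series" means these compounds.

Compound 1 `COc1ccc(N(C)c2nc(C)nc3ccccc23)cc1[Se]C`: 3 nM
Compound 2 `COc1ccc(N(C)c2nc(C)nc3ccccc23)cc1OCCN`: 421 nM

Both numbers come from a functional assay on LoVo cells (Homo sapiens) for inhibition, read by MTT assay, with a stated time of 48 h; a higher number here means a weaker inhibitor, a lower number a stronger inhibitor. Compound 2, at 421 nM, has the higher of the two numbers, which makes it the weaker inhibitor, and the gap is large: a 140-fold higher number from compound 1 to compound 2 (2.15 log units; beyond the scatter). In that step, the only one measured, the selenium-bearing group of compound 1 gives way to a longer group holding oxygen and nitrogen.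

Compound 3 `COc1ccc(N(C)c2nc(C)nc3ccccc23)cc1OCCCCC[Se]C#N` keeps the shared core and alters the end of the chain of compound 2: a group of 6 heavy atoms (4 carbon, 1 nitrogen, 1 selenium; no ring) in place of one nitrogen atom, on a saturated chain carbon, two bonds along the chain from an oxygen on an aromatic ring. The amino group leaves, and the group that enters holds selenium, as compound 1 does, along with a triple bond.

One step cannot show how much of the gap belongs to selenium, and the selenium of compound 3 sits in a different group from that of compound 1. Compound 1, at 3 nM, therefore serves only as a distant reference point, and only part of the gap is expected to close in this assay. The estimated change is a moderate move to a lower number: a 7.0-fold lower number from compound 2 to compound 3 (0.85 log units; beyond the scatter). For compound 3 the expected value is 60 nM, with a range of 8 nM to 450 nM.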

Compound 3, half-maximal inhibitory concentration: 5210 nM
Compound 3: the middle estimate sits 87-fold (1.94 log units) below what was measured; measured number above the stated range.
By their numbers in this assay, from the lowest: compound 1; then compound 2; then compound 3.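

Selenium alone does not bring a low number at this position: putting the selenium group with its triple bond in place of the amino group at the end of the chain gives a 12-fold higher number from compound 2 to compound 3 (1.09 log units; beyond the scatter) in this assay and takes the series the wrong way. The step of a 1700-fold higher number from compound 1 to compound 3 (3.24 log units; beyond the scatter) now sets two selenium compounds at opposite ends of the three numbers, with the amino compound 2 between them, so what counts in this small set is the group that holds the selenium and where it sits, not the mere presence of the element. Nothing available on these compounds accounts for this result.

The compounds shown leave open whether the chain itself or the group at its end carries most of the loss, since a shorter chain ending in the same selenium group, or the same chain ending in a methylselenyl group, would separate the two. They also leave open how far the amino end can be changed in other ways, for instance to a dimethylamine or a carboxylic acid on the same chain.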